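Varying the Substituent on the Ring Nitrogen

The source may report more compounds than this note shows. Statements on the series, on what has been measured and on what is new or still open speak of the compounds shown alone.

compound 1 `NC(=O)c1c(NC(=O)c2ccccc2Cl)sc2c1CCNC2`: 18600 nM in a functional assay on HL-60 cells (Homo sapiens) for antiproliferative activity, with a stated time of 24 h; on this read-out lower numbers stand for stronger inhibition and higher numbers for weaker inhibition
compound 2 `NC(=O)c1c(NC(=O)c2ccccc2Cl)sc2c1CCN(Cc1ccccc1)C2`: 12000 nM in this assay
compound 3 `NC(=O)c1c(NC(=O)c2ccccc2Cl)sc2c1CCN(Cc1ccc([N+](=O)[O-])cc1)C2`: 11400 nM in this assay

Compound 3 gives the lowest of these three numbers in this assay, yet its gaps to compound 2 and to compound 1 both lie within the scatter, so the three stand level. Compound 4 `NC(=O)c1c(NC(=O)c2ccccc2Cl)sc2c1CCN(C(=O)Nc1ccccc1Cl)C2` arises from compound 3 by (2-chlorophenyl)carbamoyl in place of 4-nitrobenzyl on an amine nitrogen in a ring. For the measured compounds named here, no measured step makes this exact change; the bearing steps are a 1.6-fold lower number from compound 1 to compound 2 (0.19 log units; within the scatter), a 1.6-fold lower number from compound 1 to compound 3 (0.21 log units; within the scatter) and a 1.1-fold lower number from compound 2 to compound 3 (0.02 log units; within the scatter), each within the scatter. Going by the values given here, since the group on the amine nitrogen in the ring has not moved the number so far, compound 4 is expected to show a 1.0-fold lower number from compound 3 to compound 4 (0.02 log units; within the scatter), no step beyond the scatter. Compound 4 is therefore estimated at 11000 nM, between 3500 nM and 35000 nM.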

Compound 4, half-maximal inhibitory concentration: 12500 nM
The estimate for compound 4 lay 1.1-fold (0.06 log units) below the measured number; the range from low to high includes it.
By their numbers in this assay, from the lowest: compounds 3, 2, 4 and 1 (each within the scatter of the next).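

Putting (2-chlorophenyl)carbamoyl on the amine nitrogen in the ring brings in a hydrogen-bond donor and a chlorine, yet in this assay every new comparison stays within the scatter: a 1.1-fold higher number from compound 3 to compound 4 (0.04 log units; within the scatter) and a 1.0-fold higher number from compound 2 to compound 4 (0.02 log units; within the scatter) and a 1.5-fold lower number from compound 1 to compound 4 (0.17 log units; within the scatter). The flat response at this position thus extends beyond benzyl groups to a group attached through a carbonyl. Nothing available explains this flat response.

As far as these compounds go, whether a carboxylic acid or an amine on the added ring, or a longer chain on this nitrogen, would move the number remains open. So does whether changes elsewhere on the shared core would do so.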